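The source may report more compounds than this note shows. Statements on the series, on what has been measured and on what is new or still open speak of the compounds shown alone.

In a functional assay on HL-60 cells (Homo sapiens) for inhibition, read by MTT assay, with a stated time of 72 h (a lower number here means a stronger inhibitor, a higher number a weaker inhibitor), the measured compounds are these
Compound 1 `Cc1nc(-c2ccc(F)cc2)c(C(=O)N2CCN(c3ccc(C(=O)C(C)C)cc3)CC2)o1` gives "not active" (no number reported) with no number
Compound 2 `Cc1nc(-c2ccccc2)c(C(=O)N2CCN(c3ccc(C(F)(F)F)cc3)CC2)o1` gives > 1000 nM as a limit
Compound 3 `Cc1nc(-c2ccccc2)c(C(=O)N2CCN(c3ccc(F)cc3)CC2)o1` gives > 1000 nM as a limit

Compound 3 holds only > 1000 nM as its entry, and this is a limit, not a number. The series offers the limit of > 1000 nM in this assay, at which 2 of the 3 values shown sit, and no measured number for any compound. Compound 4 `Cc1nc(-c2ccccc2)c(C(=O)N2CCN(c3ccc(C(=O)C(C)C)cc3)CC2)o1` follows from compound 3 by isopropylcarbonyl in place of fluoro on an aromatic carbon, para to a large group (isopropylcarbonyl in place of fluoro on an aromatic carbon). For the measured compounds named here, the one measured step, a step that the two limits leave unreadable from compound 2 to compound 3, has no readable size and so sets no expectation for this change. Compound 1 already carries the isopropylcarbonyl group and gives "not active" (no number reported) with no number, which offers no sign of a gain. No clear strengthening is therefore expected in this assay on this change. The expected step is a step that the limit leaves unreadable from compound 3 to compound 4 on this estimate. For compound 4 the estimated half-maximal inhibitory concentration is 2000 nM with 300 nM to 10000 nM as the expected range.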

Compound 4, half-maximal inhibitory concentration: "not active" (no number reported)
Nothing numeric was reported for compound 4; there is nothing to compare the estimate with.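

In this assay compound 4 gives "not active" (no number reported), so no step can be read between compound 3 and compound 4. The compounds shown leave open whether any of them reaches a measurable half-maximal inhibitory concentration in this assay, and how isopropylcarbonyl and fluoro truly compare there.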